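Halogen exchange on the exocyclic alkene of compound 2

The source may hold more compounds than are shown below. What is called first, only, known or untested is meant among the compounds shown, and "the series" means these compounds.

For the measured compounds named here, compound 2 `CCC[C@@H](O)C1=C(Br)/C(=C/Br)OC1=O` is the only member of this set with a full number in a functional assay on LNCaP cells (Homo sapiens) for cytotoxicity (a lower number here means that less compound is needed, a higher number that more compound is needed for the effect), where compound 2 gives 0.2 ug/mL. Compound 1 `CCC[C@@H](O)C1=C(Br)/C(=C/I)OC1=O` reaches only a limit of the assay, and for compound 1 that limit is < 0.1 ug/mL. Going by the values given here, the one measured step, an at least 2.0-fold higher number from compound 1 to compound 2 (0.30 log units; that floor lies within the scatter), bears on the next change, though its floor is set by the limit of < 0.1 ug/mL in this assay, at which 1 of the 2 values shown sits. Compound 3 `CCC[C@@H](O)C1=C(Br)/C(=C/Cl)OC1=O` differs from compound 2 by chloro in place of bromo on a double-bonded chain carbon bound to a double-bonded ring carbon. Repeating that direction of change is expected to give a step of about a 1.5-fold higher number from compound 2 to compound 3 (0.18 log units; within the scatter), within the scatter. Compound 3 is therefore estimated at 0.3 ug/mL, with a range from 0.1 ug/mL to 1 ug/mL.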

Compound 3, concentration for half-maximal effect: 3 ug/mL
Compound 3: the middle estimate sits 10-fold (1.00 log units) below what was measured; the whole stated range lies below it.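

In this assay this position proves sensitive to the halogen: a 15-fold higher number from compound 2 to compound 3 (1.18 log units; beyond the scatter) is beyond the scatter, while the earlier exchange of iodo for bromo showed only a floor within it. Compound 3, with chloro, is thus the least potent of the three, and an at least 30-fold higher number from compound 1 to compound 3 (1.47 log units; beyond the scatter) is likewise only a floor: the limit of < 0.1 ug/mL in this assay, at which 1 of the 3 values shown sits.

On these data alone, whether iodo and bromo truly differ at this place stays open. So does how a fluoro, a methyl or a nitrile on the same carbon would compare with chloro.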